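The source may report more compounds than this note shows. Statements on the series, on what has been measured and on what is new or still open speak of the compounds shown alone.

Measured compounds:
- compound 1, `CC(C)Oc1cc([N+](=O)[O-])ccc1NS(C)(=O)=O`: 5870 nM
- compound 2, `CCCCCCOc1cc([N+](=O)[O-])ccc1NS(C)(=O)=O`: 2670 nM
- compound 3, `CC(C)Oc1cc([N+](=O)[O-])ccc1N(C)S(C)(=O)=O`: 2810 nM

In an assay on SK-BR-3 cells for inhibition of Aromatase (Homo sapiens) (a higher number here means a weaker inhibitor, a lower number a stronger inhibitor), compound 3 gives 2810 nM, which places it second highest of the three numbers. Its nearest neighbour is compound 2, whose value lies within the scatter of that of compound 3, so no order between the two can be claimed. Compound 1 stands further off, and the step of a 2.1-fold lower number from compound 1 to compound 3 (0.32 log units; beyond the scatter) is beyond the scatter.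

Compound 4, `CCC(CC)Oc1cc([N+](=O)[O-])ccc1N(C)S(C)(=O)=O`, is the next member and has not yet been measured. It differs from compound 3 in one place: pentan-3-yl in place of isopropyl on an oxygen on an aromatic ring. Of the measured steps, the one that bears on this change is a 2.2-fold lower number from compound 1 to compound 2 (0.34 log units; beyond the scatter), where a longer chain replaced isopropyl on the same oxygen and the number fell modestly. The step of a 2.1-fold lower number from compound 1 to compound 3 (0.32 log units; beyond the scatter) concerns the sulfonamide nitrogen, which is unchanged between compound 3 and compound 4, and does not inform this change. Pentan-3-yl is a smaller extension than hexyl, so a somewhat smaller drop than that seen from compound 1 to compound 2 is expected, and it could fall within the scatter. Compound 4 is therefore estimated at 1900 nM, with a range of 900 nM to 4200 nM, corresponding to an expected step of a 1.5-fold lower number from compound 3 to compound 4 (0.17 log units; within the scatter).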

Compound 4, half-maximal inhibitory concentration: 230 nM
Estimate against measurement, compound 4: 8.3-fold (0.92 log units) above; the measured number lies below the stated range.
By their numbers in this assay, from the lowest: compound 4; then compounds 2 and 3 (each within the scatter of the next); then compound 1.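

In this assay, within the data shown here, the group on the oxygen on the aromatic ring carries far more weight than the earlier compounds showed: the large step of a 12-fold lower number from compound 3 to compound 4 (1.09 log units; beyond the scatter) stands against the modest step of a 2.2-fold lower number from compound 1 to compound 2 (0.34 log units; beyond the scatter) at the same place. The change is small by count, with pentan-3-yl bringing 5 heavy atoms where isopropyl has 3, and no ring, hydrogen-bond donor, hydrogen-bond acceptor or net charge enters with it. No measurement at hand bears on why this exchange gives so large a step.

The compounds shown leave open whether pentan-3-yl would give a step of this size with hydrogen on the sulfonamide nitrogen, and whether hexyl would do the same with methyl there. They also leave open whether the large step belongs to pentan-3-yl alone or would also appear with a cyclopentyl ring or a longer chain on the same oxygen.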